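The source may report more compounds than this note shows. Statements on the series, on what has been measured and on what is new or still open speak of the compounds shown alone.

Measured so far in a functional assay on HepG2 cells (Homo sapiens) for cytotoxicity, read by MTT assay, with a stated time of 24 h; a higher number here means a weaker inhibitor, a lower number a stronger inhibitor:
- compound 1, `O=C1/C(=C/c2cccnc2)CNC/C1=C\c1ccccc1F`: 21000 nM
- compound 2, `O=C1/C(=C/c2cccnc2)CN(S(=O)(=O)c2ccc(C(F)(F)F)cc2)C/C1=C\c1ccccc1F`: 2400 nM
- compound 3, `O=C1/C(=C/c2cccnc2)CN(S(=O)(=O)c2ccc(F)cc2)C/C1=C\c1ccccc1F`: 15600 nM

Compound 1 gives the highest number of the three. Its nearest neighbour is compound 3, and the step of a 1.3-fold lower number from compound 1 to compound 3 (0.13 log units; within the scatter) lies within the scatter, so no order can be read between these two. The change that separates them is hydrogen in place of (4-fluorophenyl)sulfonyl on an amine nitrogen in a ring. Within the data shown here, the one clear step in this assay is a 6.5-fold lower number from compound 3 to compound 2 (0.81 log units; beyond the scatter), which comes from the change (trifluoromethyl in place of fluoro on an aromatic carbon).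

Compound 4, `O=C1/C(=C/c2cccnc2)CNC/C1=C\c1ccccc1C(F)(F)F`, has not been measured. It differs from compound 1 by trifluoromethyl in place of fluoro on an aromatic carbon. Among the measured compounds shown here, this is the same kind of change as the one from compound 3 to compound 2, but not the same: in compound 2 the trifluoromethyl sits para to a large group on the sulfonyl-bearing ring, whereas in compound 4 it sits ortho to a large group on a ring of the shared core. The two cores differ as told by hydrogen in place of (4-fluorophenyl)sulfonyl on an amine nitrogen in a ring. For the measured compounds named here, only one measured instance of this kind of change exists here, and it sits on a different ring, so it is a weak guide.

In this assay compound 4 is expected to show a step of about a 2.3-fold lower number from compound 1 to compound 4 (0.37 log units; beyond the scatter) relative to compound 1, smaller than a 6.5-fold lower number from compound 3 to compound 2 (0.81 log units; beyond the scatter). That step was measured at a different place on a different ring. The estimate for compound 4 is 9000 nM, with a likely range from 3000 nM to 25000 nM.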

Compound 4, half-maximal inhibitory concentration: 5020 nM
Beside the measured number, compound 4's estimate is 1.8-fold (0.25 log units) above it, within the range that was stated.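

In this assay, trifluoromethyl in place of fluoro on an aromatic carbon, ortho to a large group, gives a 4.2-fold lower number from compound 1 to compound 4 (0.62 log units; beyond the scatter), so the change on the core of compound 1 lowers the number beyond the scatter. Set beside the earlier step, the change goes in the same direction on both cores and the two sizes cannot be told apart: the same change on two cores in this assay, a 6.5-fold lower number (0.81 log units; beyond the scatter) from compound 3 to compound 2 and a 4.2-fold lower number (0.62 log units; beyond the scatter) from compound 1 to compound 4, 1.6-fold (0.19 log units) apart, within the scatter of two such steps This supports carrying the change between these two cores as a working rule for this cytotoxicity read-out, but it rests on two pairs only, with the change at a different place in each, so it does not separate the effect of the core from that of the place, does not explain the lowering, and does not show that the step would hold on any further core.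

Still open, as far as these compounds go, is whether the lower number is specific to trifluoromethyl, since chloro, methoxy or nitrile on the same aromatic carbon would test this. Also open, from the compounds shown here alone, is how a compound carrying trifluoromethyl at both places would compare, and how an amine or a carboxylic acid on the arylsulfonyl group would read.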